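The source may report more compounds than this note shows. Statements on the series, on what has been measured and on what is new or still open speak of the compounds shown alone.

Measured compounds in an assay on Sf9 cells for inhibition of histone deacetylase 11 (Homo sapiens), read by fluorescence, tested at 0.5 uM; on this read-out higher numbers stand for more inhibition at the one concentration tested (going by the name of the read-out) and lower numbers for less inhibition:

- compound 1 `O=C(NO)c1ccc(-c2cn([C@@H]3C[C@H](C(=O)O)N(CCCc4ccccc4)C3)nn2)cc1`: < 10% (a limit of the assay, not a number)
- compound 2 `O=C(NO)c1ccc(-c2cn([C@@H]3C[C@H](C(=O)O)N(Cc4ccccc4)C3)nn2)cc1`: < 10% (likewise a limit)
- compound 3 `O=C(NO)c1ccc(-c2cn([C@H]3C[C@@H](C(=O)O)N(CCCc4ccccc4)C3)nn2)cc1`: 14%

Compound 1 sits at the limit of this assay, not at a measured number. The same holds for compound 2, so that two of the three values rest on (the limit of < 10% in this assay, at which 2 of the 3 values shown sit). Only compound 3 returns a number, and that one sits close to the limit itself.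

Two steps start from compound 1. The first, a step that the two limits leave unreadable from compound 1 to compound 2, cannot be read, as both ends are limits. The second, a number at least 4 percentage points higher from compound 1 to compound 3 (that floor lies within the scatter), is a step whose floor stays within the scatter of repeated measurements; the two compounds share every atom and bond and differ only as described by the fact that compounds 1 and 3 differ only in the configuration as drawn. Neither step touches the part of compound 1 that changes on the way to compound 4.

Compound 4 `O=C(/C=C/c1cn([C@@H]2C[C@H](C(=O)O)N(CCCc3ccccc3)C2)nn1)NO` differs from compound 1 in one place: 2-(hydroxycarbamoyl)ethenyl in place of 4-(hydroxycarbamoyl)phenyl on an aromatic carbon. Going by the values given here, no measured pair in this small set carries that change, so the expectation can rest only on the level at which compound 1 stands. Compound 4 is therefore expected to remain close to the limit in this assay, with an estimated step that the limit leaves unreadable from compound 1 to compound 4, that is, no step beyond the scatter. The estimate for compound 4 is 8%, between 0% and 20%.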

Compound 4, a percentage reported as inhibition, at one concentration (the size of the read-out at that concentration, not a potency): 11%
Estimate against measurement, compound 4: 3 percentage points below; measured number inside the range.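

Going by these compounds alone, at the aromatic carbon of the five-membered aromatic ring with 3 nitrogen, putting 2-(hydroxycarbamoyl)ethenyl in place of 4-(hydroxycarbamoyl)phenyl gives a number at least 1 percentage points higher from compound 1 to compound 4 (that floor lies within the scatter) in this assay, the first reading for this position. Compound 1 gives < 10%, which is a limit of the assay and not a number. Compound 4, whose group has no ring, returns 11%, so the six-membered aromatic ring of carbon only is not required for a numerical reading in this assay. The size of the step remains unfixed because one end of it is a limit, and the series as a whole stays close to that limit: the limit of < 10% in this assay, at which 2 of the 4 values shown sit.

Going by these compounds, it remains open whether the same exchange would behave alike on the mirror-image core of compound 3 or with the shorter ring-nitrogen substituent of compound 2. Also open, on these data alone, is how a saturated chain carrying the hydroxycarbamoyl group, or a carboxylic acid in its place, would read at this position, and whether any of these changes would move the value beyond the scatter.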